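The source may report more compounds than this note shows. Statements on the series, on what has been measured and on what is new or still open speak of the compounds shown alone.

Working notes on the 2-aminothiophene amide series.

Three amides of the shared core have numbers in a functional assay on A549 cells (Homo sapiens) for inhibition, read by sulforhodamine B assay, with a stated time of 72 h; on this read-out lower numbers stand for stronger inhibition and higher numbers for weaker inhibition. Compound 1 `Nc1sc(-c2ccc(Cl)cc2)c(-c2ccc(Cl)cc2)c1C(=O)NC1CCCCC1` gives 2410 nM. Compound 2 `Nc1sc(-c2ccc(Cl)cc2)c(-c2ccc(Cl)cc2)c1C(=O)NCc1ccccc1` gives 16300 nM, and compound 3 `COc1ccc(CNC(=O)c2c(N)sc(-c3ccc(Cl)cc3)c2-c2ccc(Cl)cc2)cc1` gives 18200 nM. Compound 3 stands highest of the three numbers; its nearest neighbour is compound 2, within the scatter, and its furthest is compound 1. The step of a 7.6-fold higher number from compound 1 to compound 3 (0.88 log units; beyond the scatter) and the step of a 6.8-fold higher number from compound 1 to compound 2 (0.83 log units; beyond the scatter) are both modest and beyond the scatter, while the step of a 1.1-fold higher number from compound 2 to compound 3 (0.05 log units; within the scatter) is within it.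

Compound 4 `Nc1sc(-c2ccc(Cl)cc2)c(-c2ccc(Cl)cc2)c1C(=O)N1CCC(=O)CC1=O` has not been run in this assay. It differs from compound 3 in one place: 2,4-dioxopiperidin-1-yl in place of (4-methoxybenzyl)amino on a carbonyl carbon. Among the measured compounds shown here, no measured step touches this kind of change; both earlier steps exchange one substituent on the amide-type nitrogen, whereas here the nitrogen becomes part of a six-membered non-aromatic ring carrying two carbonyls. The only guide is that the one compound with a six-membered non-aromatic ring on the nitrogen, compound 1, gives 2410 nM, the lowest number shown. The step back toward that level is expected to be a 2.3-fold lower number from compound 3 to compound 4 (0.36 log units; beyond the scatter), with wide uncertainty. Compound 4 is estimated at 8000 nM, within a range from 2000 nM to 32000 nM.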

Compound 4, half-maximal inhibitory concentration: 4090 nM
Compound 4: middle estimate off by 2.0-fold (0.29 log units), on the high side; the range from low to high includes it.
By their numbers in this assay, from the lowest: compounds 1 and 4 (each within the scatter of the next); then compounds 2 and 3 (each within the scatter of the next).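

In this assay the carbonyl carbon accepts a group in which the nitrogen sits inside a six-membered non-aromatic ring and no amide hydrogen remains, and the number still falls, with a 4.4-fold lower number from compound 3 to compound 4 (0.65 log units; beyond the scatter) and a 4.0-fold lower number from compound 2 to compound 4 (0.60 log units; beyond the scatter) both beyond the scatter. Against the cyclohexyl amide the change gives a 1.7-fold higher number from compound 1 to compound 4 (0.23 log units; within the scatter) and stays within the scatter, so compounds 1 and 4 cannot be ordered, and among these four amides the two with a six-membered non-aromatic ring both stand apart from the two with a benzyl-type group, despite their different ring and nitrogen arrangement. Nothing available gives a reason for these differences.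

As far as these compounds go, it remains open whether the two ring carbonyls of compound 4 matter at all, which a plain piperidin-1-yl group on the same carbonyl carbon would separate from the effect of the ring itself. From the compounds shown here alone, it is equally open whether the amide hydrogen of compound 1 has any bearing on its number, a question that a cyclohexyl(methyl)amino group would put directly.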